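Swapping the aryl group on the four-membered core

The source may hold more compounds than are shown below. What is called first, only, known or untested is meant among the compounds shown, and "the series" means these compounds.

Of the compounds shown here, three that share a four-membered core have been tested in a functional assay on MCF7 cells (Homo sapiens) for antiproliferative activity, read by MTT assay, with stated times of 24 h and 72 h; a higher number here means a weaker inhibitor, a lower number a stronger inhibitor. Compound 1 `COc1cc([C@@H]2[C@H](Oc3ccccc3)C(=O)N2c2cc(OC)c(OC)c(OC)c2)cc(OC)c1OC` gives 29000 nM. Compound 2 `COc1cc(N2C(=O)[C@@H](Oc3ccccc3)[C@H]2c2ccc(N(C)C)cc2)cc(OC)c1OC` gives 31000 nM. Compound 3 `COc1cc(N2C(=O)[C@@H](Oc3ccccc3)[C@H]2c2ccc(N=[N+]=[N-])cc2)cc(OC)c1OC` gives 23000 nM. All three numbers sit within the scatter of one another: the step of a 1.1-fold higher number from compound 1 to compound 2 (0.03 log units; within the scatter) and the step of a 1.3-fold lower number from compound 2 to compound 3 (0.13 log units; within the scatter) are both small, and compound 1 is the nearer neighbour of compound 2, compound 3 the further one.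

Compound 4 `COc1ccc([C@@H]2[C@H](Oc3ccccc3)C(=O)N2c2cc(OC)c(OC)c(OC)c2)cc1N` has not yet been measured. It differs from compound 2 in one place: 3-amino-4-methoxyphenyl in place of 4-(dimethylamino)phenyl on a saturated ring carbon.

Within the data shown here, the steps that bear on this change are those that also swap the aryl group on the saturated ring carbon, namely a 1.1-fold higher number from compound 1 to compound 2 (0.03 log units; within the scatter) and a 1.3-fold lower number from compound 1 to compound 3 (0.10 log units; within the scatter). Neither moved the number beyond the scatter, so the expected step of a 1.1-fold lower number from compound 2 to compound 4 (0.04 log units; within the scatter) is none beyond the scatter. Compound 4 is therefore estimated at 28000 nM in this assay, with a range from 12000 nM to 65000 nM.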

Compound 4, half-maximal inhibitory concentration: 12200 nM
Compound 4: the middle estimate sits 2.3-fold (0.36 log units) above what was measured; the range from low to high includes it.
By their numbers in this assay, from the lowest: compounds 4, 3, 1 and 2 (each within the scatter of the next, the first and the last beyond it).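

This position is not indifferent to the aryl group after all. Among these compounds, with 3-amino-4-methoxyphenyl on the saturated ring carbon comes a 2.5-fold lower number from compound 2 to compound 4 (0.41 log units; beyond the scatter) and a 2.4-fold lower number from compound 1 to compound 4 (0.38 log units; beyond the scatter), the first steps here to pass the scatter, though both are modest, while a 1.9-fold lower number from compound 3 to compound 4 (0.28 log units; within the scatter) stays within it, so compound 4 stands apart from compound 1 and compound 2 but not from compound 3. Nothing at hand accounts for this shift.

The entering group brings an amino group and a methoxy group together, and these compounds cannot show whether either one alone would give the same step. As far as these compounds go, a hydroxyl or an acetamide in place of the amino group, or a phenyl ring carrying only the methoxy group, remains open at this position.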